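The compounds below may be only part of what the source reports. "The series", "measured", "known", "first", "only" and "open" are said of these compounds alone.

In a physicochemical assay for lipophilicity, at pH 7.4 (a lower number here means a more polar compound, a higher number a more lipophilic compound), compound 1 `Cc1cccc(C)c1-c1cccc(COc2ccc(CCC(=O)O)s2)c1` gives > 2.4, which is a limit of the assay and not a number. Compound 2 `Cc1cccc(C)c1-c1cccc(COc2ccc(CC(F)C(=O)O)cn2)c1` offers no number at all: its entry reads "not determined" (no result reported). Compound 2 therefore stands without a value of its own, and the only figure nearby is that limit for a different compound. Compound 3 `Cc1cccc(C)c1-c1cccc(COc2ccc(C(C)CC(=O)O)cn2)c1` is still to be measured. The change 1-(carboxymethyl)ethyl in place of 2-carboxy-2-fluoroethyl on an aromatic carbon puts 1-(carboxymethyl)ethyl in place of 2-carboxy-2-fluoroethyl on an aromatic carbon of a six-membered aromatic ring with 1 nitrogen, para to a large group. Among the measured compounds shown here, no measured step exists to size this change, so no shift beyond the usual scatter is expected in this assay, in either direction. The expectation leans on compound 1 at > 2.4, again only a limit. For compound 3 the estimated value is 2.3, with an expected range of 1.8 to 2.8.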

Compound 3, distribution coefficient: 3.3
Compound 3: the middle estimate sits 1.00 log units below what was measured, and the stated range ends below it.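

Among the compounds shown here, compound 2 has no number in this assay, so no step to compound 3 can be read from this result. The compounds shown leave open how far 1-(carboxymethyl)ethyl in place of 2-carboxy-2-fluoroethyl shifts the distribution coefficient, and in which direction.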